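This account rests on a few compounds, and the source may have more. Where it says the series, first, only, none or still open, it means among the compounds named here.

In a functional assay on A549 cells (Homo sapiens) for antiproliferative activity, read by MTT assay, with a stated time of 72 h (on this read-out lower numbers stand for stronger inhibition and higher numbers for weaker inhibition), compound 1 `NC1=NC2(CCSCC2)N(OCCCOc2ccc(Cl)c(Cl)c2)C(N)=N1` gives 1 nM. Compound 2 `NC1=NC2(CCSCC2)N(OCCCOc2cccc(Cl)c2)C(N)=N1` differs from compound 1 by hydrogen in place of chloro on an aromatic carbon, and in this assay compound 2 gives 60 nM; this single change made a step of a 60-fold higher number from compound 1 to compound 2 (1.78 log units; beyond the scatter).

Compound 3 `NC1=NC2(CCOCC2)N(OCCCOc2cccc(Cl)c2Cl)C(N)=N1` carries a different core, and the difference between the two cores is not broken down here. In this assay compound 3 gives 100 nM, the highest of the three numbers, though its gap to compound 2 lies within the scatter.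

Compound 4 `NC1=NC2(CCOCC2)N(OCCCOc2ccccc2Cl)C(N)=N1` is not yet measured. It differs from compound 3 by hydrogen in place of chloro on an aromatic carbon. Among the compounds with values here, this is the same kind of change as the one from compound 1 to compound 2, but not the same: in compound 1 the chloro that leaves sits para to a large group, in compound 3 it sits meta to a large group, and the cores differ as well.

Because the earlier step of a 60-fold higher number from compound 1 to compound 2 (1.78 log units; beyond the scatter) was large, a step in the same direction is expected for compound 4, though a smaller one, given the different place and core. The expected step for compound 4 is a 10-fold higher number from compound 3 to compound 4 (1.00 log units; beyond the scatter). Compound 4 is therefore estimated at 1000 nM, expected to lie between 300 nM and 5000 nM.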

Compound 4, half-maximal inhibitory concentration: 2700 nM
The estimate for compound 4 lay 2.7-fold (0.43 log units) below the measured number; the measured number falls inside the stated range.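

In this assay, replacing chloro with hydrogen on the aromatic ring, here the change from 2,3-dichlorophenyl to 2-chlorophenyl, produces a 27-fold higher number from compound 3 to compound 4 (1.43 log units; beyond the scatter). The same change therefore gives a large step toward weaker inhibition on both cores, and the two steps do not differ in size: the same change on two cores in this assay, a 60-fold higher number (1.78 log units; beyond the scatter) from compound 1 to compound 2 and a 27-fold higher number (1.43 log units; beyond the scatter) from compound 3 to compound 4, 2.2-fold (0.35 log units) apart, within the scatter of two such steps. This shows that, in these two pairs, the loss on removing a chloro carried over from one core to the other, even though the chloro leaves a different place on the ring in each pair, but two pairs do not show that it would hold on any further core, and they do not separate the role of the core from that of the chloro's place.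

The compounds shown leave open how the two cores compare with one aryl group held fixed. They also leave open whether a fluoro, methyl or methoxy group in place of the departing chloro, or a longer chain to the aryl ether, would keep the numbers low.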